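A Pyridine Isomer on the Shared Core

The source may report more compounds than this note shows. Statements on the series, on what has been measured and on what is new or still open speak of the compounds shown alone.

Compound 1 `CCN(CC)C(=O)[C@@]1(c2cccnc2)C[C@H]1CN` was tested in an assay on HEK293 cells for inhibition of sodium-dependent dopamine transporter (Homo sapiens) (on this read-out higher numbers stand for weaker inhibition and lower numbers for stronger inhibition), and returned only a limit of the assay, > 10000 nM. Its two companions stand where it stands. Compound 2 `CCN(CC)C(=O)[C@@]1(c2ccsc2)C[C@H]1CN(C)C` gives in this assay only a limit, > 10000 nM. Compound 3 `COCCN(C)C(=O)[C@@]1(c2ccsc2)C[C@H]1CN` likewise gives in this assay only a limit, > 10000 nM. No number is known for any of the three; all sit at the limit of > 10000 nM in this assay, at which 3 of the 3 values shown sit.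

Compound 4 `CCN(CC)C(=O)[C@@]1(c2ccccn2)C[C@H]1CN` has not been measured. It differs from compound 1 by pyridin-2-yl in place of pyridin-3-yl on a saturated ring carbon. Within the data shown here, no step between two measured compounds exists here, so the size of this change cannot be read from any neighbouring pair, and the expected step from compound 1 to compound 4 is none beyond the scatter, in no direction. Compound 1 shows in this assay only the limit > 10000 nM, and nothing measured points to a gain. Compound 4 is therefore expected to remain near that limit, with an estimate of 15000 nM ranging from 4000 nM to 60000 nM. The step this estimate means is expected to be a step that the limit leaves unreadable from compound 1 to compound 4.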

Compound 4, half-maximal inhibitory concentration: > 10000 nM
Compound 4: only a limit was reported; the forecaster's own chance of this, stated with the estimate: 75%; the middle value is on the limit's open side.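

Compound 1 and compound 4 both stand only at a limit, so no step between them can be read: the limit of > 10000 nM in this assay, at which 4 of the 4 values shown sit.

The compounds shown leave open whether any change on the shared core would give a measurable number in this assay.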